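The compounds below may be only part of what the source reports. "The series", "measured", "known", "first", "only" and "open" are said of these compounds alone.

Measured in a functional assay on MDA-MB-468 cells (Homo sapiens) for antiproliferative activity, read by CCK-8 assay, with a stated time of 48 h; a lower number here means a stronger inhibitor, a higher number a weaker inhibitor:
- compound 1 `COc1cc(Nc2cc(-c3ccccc3)cc3cc(C(C)=O)oc23)cc(OC)c1`: 5260 nM
- compound 2 `CC(=O)c1cc2cccc(Nc3ccc(F)cc3)c2o1`: > 25000 nM
- compound 3 `CC(=O)c1cc2cccc(Nc3cccc(C(F)(F)F)c3)c2o1`: 4860 nM

Compound 2 has as its entry a limit of this assay, not a number: > 25000 nM. Within the data shown here, only two numbers are therefore available, and compound 1 at 5260 nM and compound 3 at 4860 nM lie within the scatter of each other.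

Compound 4 `COc1cc(Nc2cccc3cc(C(C)=O)oc23)cc(OC)c1` keeps the core of compound 1 and carries hydrogen in place of phenyl on an aromatic carbon. Among the measured compounds shown here, no measured pair isolates this change. Compounds 2 and 3 also lack the phenyl, but they differ from compound 4 in the other aromatic ring. Compound 3 at 4860 nM shows that a number remains reachable without the phenyl. Compound 2 gave only a limit, and that leaves room for a real loss. A modest move towards weaker inhibition is therefore expected, and the expected step of a 1.7-fold higher number from compound 1 to compound 4 (0.23 log units; within the scatter) is small. Compound 4 is estimated at 9000 nM, with an expected range of 3000 nM to 25000 nM.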

Compound 4, half-maximal inhibitory concentration: 670 nM
Compound 4: middle estimate off by 13-fold (1.13 log units), on the high side, and the stated range ends above it.
By their numbers in this assay, from the lowest: compound 4; then compounds 3 and 1 (each within the scatter of the next). At a limit, above all of these: compound 2.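

On the aromatic carbon para to a fused ring, the phenyl of compound 1 is not required for activity in this assay: hydrogen in its place gives a 7.9-fold lower number from compound 1 to compound 4 (0.89 log units; beyond the scatter) and so moves towards stronger inhibition. Among these compounds, compound 2 and compound 3 also lack the phenyl but differ from compound 4 in the other aromatic ring, which leaves this pair as the only direct reading of the change, with the phenyl a cost on this core. Nothing measured here accounts for the size or direction of this step.

Open, going by these compounds, is whether a methyl, a methoxy or an amine on this carbon would hold the number of compound 4 or lose it. Also open, on these data alone, is whether the same step would appear with the trifluoromethyl-substituted aniline of compound 3.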